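A sulfonyl swap on a compound at the limit

The source may report more compounds than this note shows. Statements on the series, on what has been measured and on what is new or still open speak of the compounds shown alone.

In an ADME assay on microsomes from liver (Homo sapiens) for metabolic stability, read by LC-MS, using NADPH (on this read-out lower numbers stand for slow clearance and higher numbers for fast clearance), three compounds have been measured, each only as a limit:

- compound 1 `CCOC(=O)c1cc(C#N)c(N2CCN(C(=O)NS(=O)(=O)c3ccc(C)cc3)CC2)nc1C(F)(F)F` gives > 70000 mL.min-1.g-1 as a limit
- compound 2 `CCOC(=O)c1cc(C#N)c(N2CCN(C(=O)NS(=O)(=O)c3ccc(Cl)cc3)CC2)nc1C(F)(F)F` gives > 70000 mL.min-1.g-1 as a limit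
- compound 3 `CCOC(=O)c1cnc(N2CCN(C(=O)NS(=O)(=O)c3ccc(Cl)s3)CC2)c(Cl)c1` gives > 70000 mL.min-1.g-1 as a limit

Compound 3 stands at > 70000 mL.min-1.g-1 and this is a limit of the assay and not a number. The change to compound 4 `CCOC(=O)c1cnc(N2CCN(C(=O)NS(=O)(=O)c3ccccc3C)CC2)c(Cl)c1` is 2-methylphenyl in place of 5-chlorothiophen-2-yl on a sulfonyl sulfur and the rest of the structure stays the same. Among the measured compounds shown here, the only measured step that the two limits leave unreadable from compound 1 to compound 2 has no readable size, and the limit shared by all the measured compounds the limit of > 70000 mL.min-1.g-1 in this assay, at which 3 of the 3 values shown sit, leaves the account with no size or direction to carry over. In this assay no step beyond the scatter can therefore be foreseen, and compound 4 is expected to stay in the same region. The expected step is a number no higher from compound 3 to compound 4 (the limit leaves the size open) and it remains only an estimate. For compound 4 the estimated value is 70000 mL.min-1.g-1 with an expected range from 30000 mL.min-1.g-1 to 100000 mL.min-1.g-1 and another report as a limit is likely.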

Compound 4, intrinsic clearance in microsomes: > 70000 mL.min-1.g-1
Compound 4: only a limit was reported (the forecaster's own chance of this, stated with the estimate: 80%); the middle value sits exactly at the limit.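

Compound 3 and compound 4 are both reported only as limits in this assay, so no step between them can be read: the limit of > 70000 mL.min-1.g-1 in this assay, at which 4 of the 4 values shown sit.

The compounds shown leave open what the intrinsic clearance of any of them is, and whether 2-methylphenyl in place of 5-chlorothiophen-2-yl changes it at all.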